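A few compounds are considered here, and "the series" means these few. Any claim that something is new, unique, unknown or untested is made for them only; others in the source may bear on it.

Compound 1 `CC(C)[C@H](NC(=O)COc1cccc2ccccc12)C(=O)N[C@@H](CC(=O)O)C(=O)COc1ccccc1` gives 11200 nM in a functional assay with Homo sapiens as the target; on this read-out lower numbers stand for stronger inhibition and higher numbers for weaker inhibition. Compound 2 `CC(C)[C@H](NC(=O)COc1cccc2ccccc12)C(=O)N[C@@H](CC(=O)O)C(=O)COc1ccc(F)cc1` carries fluoro in place of hydrogen on an aromatic carbon and gives 14300 nM in this assay, a step of a 1.3-fold higher number from compound 1 to compound 2 (0.11 log units; within the scatter). Compound 3 `CC(C)[C@H](NC(=O)COc1cccc2ccccc12)C(=O)N[C@@H](CC(=O)O)C(=O)COc1c(F)c(F)cc(F)c1F` differs from compound 1 in its core by 2,3,5,6-tetrafluorophenyl in place of phenyl on an oxygen on a saturated carbon; in this assay compound 3 gives 6250 nM. Compound 4 `CC(C)[C@H](NC(=O)COc1cccc2ccccc12)C(=O)N[C@@H](CC(=O)O)C(=O)COc1c(F)c(F)c(F)c(F)c1F` is not yet measured; it differs from compound 3 by fluoro in place of hydrogen on an aromatic carbon. This is the same kind of change as that from compound 1 to compound 2, but the surroundings differ: in compound 4 the entering fluoro sits ortho to two fluoro groups and meta to two fluoro groups as well as para to a large group, whereas in compound 2 it sits only para to a large group. Because a 1.3-fold higher number from compound 1 to compound 2 (0.11 log units; within the scatter) lies within the scatter, compound 4 is expected to shift by only a 1.1-fold higher number from compound 3 to compound 4 (0.05 log units; within the scatter). Compound 4 is therefore estimated at 7000 nM in this assay, likely between 3500 nM and 14000 nM.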

Compound 4, half-maximal inhibitory concentration: 8890 nM
Beside the measured number, compound 4's estimate is 1.3-fold (0.10 log units) below it; the range from low to high includes it.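

In this assay, fluoro in place of hydrogen gives a 1.4-fold higher number from compound 3 to compound 4 (0.15 log units; within the scatter), and the same change on the two cores does not differ: the same change on two cores in this assay, a 1.3-fold higher number (0.11 log units; within the scatter) from compound 1 to compound 2 and a 1.4-fold higher number (0.15 log units; within the scatter) from compound 3 to compound 4, 1.1-fold (0.05 log units) apart, within the scatter of two such steps. The other two new comparisons, a 1.6-fold lower number from compound 2 to compound 4 (0.21 log units; within the scatter) and a 1.3-fold lower number from compound 1 to compound 4 (0.10 log units; within the scatter), also give no readable difference. This shows that the change stays too small to read on both cores, but it does not show a fixed effect of one size, and two cores are a narrow test.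

The compounds shown leave open whether a chlorine, a methoxy group or an amine in place of that fluoro would give a step beyond the scatter. They also leave open how the fluoro change behaves on other cores.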